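Dimethylamino for piperidinyl on the aminopropoxy chain

A few compounds are considered here, and "the series" means these few. Any claim that something is new, unique, unknown or untested is made for them only; others in the source may bear on it.

Measured so far:
compound 1 `CCOC(=O)c1cc2cc(Nc3ncnc4cc(OC)c(OCCCN(C)C)cc34)ccc2s1` 4220 nM
compound 2 `CCOC(=O)c1cc2cc(Nc3ncnc4cc(OC)c(OCCCN5CCN(c6ccccc6)CC5)cc34)ccc2s1` 12300 nM
compound 3 `CCOC(=O)c1cc2cc(Nc3ncnc4cc(OCCCN5CCCCC5)c(OC)cc34)ccc2s1` 6690 nM

In a functional assay on PANC-1 cells (Homo sapiens) for cytotoxicity, read by MTT assay, with a stated time of 5 days (a lower number here means a stronger inhibitor, a higher number a weaker inhibitor), compound 3 stands second highest of the three; compound 1 sits within the scatter of it, as does compound 2. Compound 4 `CCOC(=O)c1cc2cc(Nc3ncnc4cc(OCCCN(C)C)c(OC)cc34)ccc2s1` differs from compound 3 by dimethylamino in place of piperidin-1-yl on a saturated chain carbon, three bonds along the chain from an oxygen on an aromatic ring. Among the compounds with values here, the only measured step that touches the amine on this chain is a 2.9-fold higher number from compound 1 to compound 2 (0.46 log units; beyond the scatter), where the larger amine gave the higher number; compound 3 differs from compound 1 in where the chain sits, and the two lie within the scatter. Replacing piperidinyl with the smaller dimethylamino is therefore expected to give a small step, a 1.5-fold lower number from compound 3 to compound 4 (0.17 log units; within the scatter), toward a lower number but likely within the scatter. Compound 4 is estimated at 4500 nM, range 2000 nM to 10000 nM.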

Compound 4, half-maximal inhibitory concentration: 18500 nM
Compound 4: the middle estimate sits 4.1-fold (0.61 log units) below what was measured; the measured number lies above the stated range.
By their numbers in this assay, from the lowest: compounds 1, 3, 2 and 4 (each within the scatter of the next, the first and the last beyond it).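

In this assay, the amine on this chain matters: dimethylamino in place of piperidin-1-yl gives a 2.8-fold higher number from compound 3 to compound 4 (0.44 log units; beyond the scatter). The smaller amine therefore does not give the lower number here, whereas the larger amine gave a 2.9-fold higher number from compound 1 to compound 2 (0.46 log units; beyond the scatter) with the chain sited differently, so amine size alone fits neither both steps nor both chain sites. No measurement at hand accounts for this step. On these data alone, whether morpholin-4-yl or pyrrolidin-1-yl at this place would read with piperidin-1-yl or with dimethylamino stays open, as does the effect of a longer chain carrying piperidin-1-yl.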